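This account rests on a few compounds, and the source may have more. Where it says the series, first, only, none or still open, it means among the compounds named here.

Of the compounds shown here, two have numbers so far in a functional assay on U-251 cells (Homo sapiens) for antiproliferative activity, read by sulforhodamine B assay, with a stated time of 48 h; on this read-out higher numbers stand for weaker inhibition of growth and lower numbers for stronger inhibition of growth. Compound 1 (`CCCCCC[C@@H](O)C/C=C\CCCCCCCC(=O)N1CCOCC1`) gives 33.1 ug/mL, and compound 2 (`CCCCCCCC/C=C\CCCCCCCC(=O)N1CCCCC1`) gives 6.7 ug/mL, the lower of the two numbers and beyond the scatter from compound 1.

Compound 3 (`CCCCCCCC/C=C\CCCCCCCC(=O)N1CCOCC1`) keeps the rest of compound 2 and changes one group: morpholin-4-yl in place of piperidin-1-yl on a carbonyl carbon, with morpholin-4-yl in place of piperidin-1-yl on a carbonyl carbon. Within the data shown here, no measured pair isolates this change, so the expectation rests on thin evidence. Compound 1 also carries morpholin-4-yl and stands at 33.1 ug/mL, but it differs from compound 2 elsewhere too, so it serves only as a loose guide to direction. A shift toward weaker inhibition of growth is expected, with an estimated 2.4-fold higher number from compound 2 to compound 3 (0.38 log units; beyond the scatter), modestly beyond the scatter. Compound 3 is estimated at 16 ug/mL, with an expected range of 6.5 ug/mL to 40 ug/mL.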

Compound 3, concentration for 50% growth inhibition: 2.8 ug/mL
Beside the measured number, compound 3's estimate is 5.7-fold (0.76 log units) above it; measured number below the stated range.
By their numbers in this assay, from the lowest: compound 3; then compound 2; then compound 1.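

Among these compounds, on the carbonyl carbon, morpholin-4-yl in place of piperidin-1-yl gives a 2.4-fold lower number from compound 2 to compound 3 (0.38 log units; beyond the scatter) in this assay, the first matched reading of this change, and it runs toward stronger inhibition of growth. Hydrogen in place of hydroxy on a saturated chain carbon bound to two saturated chain carbons gives a 12-fold lower number from compound 1 to compound 3 (1.07 log units; beyond the scatter), so the weak number of compound 1 goes with the hydroxy and not with the morpholin-4-yl that compound 3 also carries. No measurement at hand accounts for either step.

From the compounds shown here alone, each change rests on a single pair, so it remains open whether morpholin-4-yl would still give the lower number than piperidin-1-yl on the hydroxy-bearing chain. Also open, going by these compounds, is how a dimethylamino group or a free hydroxy forming a carboxylic acid would read on the carbonyl carbon, and how a shorter chain would read with morpholin-4-yl kept.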